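The source may hold more compounds than are shown below. What is called first, only, known or untested is meant among the compounds shown, and "the series" means these compounds.

Compound 2 `COc1ccc2c(c1)CCC(Cc1ccccc1C(F)(F)F)C2=O` holds the lowest number of the three measured in an assay on CHO cells for inhibition of 1,25-dihydroxyvitamin D(3) 24-hydroxylase, mitochondrial (Homo sapiens); a higher number here means a weaker inhibitor, a lower number a stronger inhibitor: compound 2 gives 2080 nM. Its nearest neighbour is compound 3 `COc1ccc2c(c1)CC/C(=C\c1ccccc1Br)C2=O`, which in this assay gives 122000 nM, and the furthest is compound 1 `COc1ccc2c(c1)CC/C(=C\c1ccccc1C)C2=O`, which gives 480000 nM. For the measured compounds named here, the only step measured between compounds that differ in one place runs between those two, a 3.9-fold lower number from compound 1 to compound 3 (0.59 log units; beyond the scatter). Compounds 1 and 3 differ from compound 2 in more than one place, so their values can only be set side by side with it, not read as a single step.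

Compound 4 `COc1ccc2c(c1)CCC(Cc1ccccc1-c1ccccc1)C2=O` differs from compound 2 in one place: phenyl in place of trifluoromethyl on an aromatic carbon. Going by the values given here, no measured step bears on this exchange; the one step on record concerns bromo for methyl and lies on the other pair of compounds, and it says nothing about phenyl or trifluoromethyl. With nothing to go on but the position of compound 2 and the absence of a directly comparable step, a modest move is expected, more likely towards a higher number than a lower one, with wide uncertainty, and the step from compound 2 is estimated as a 1.9-fold higher number from compound 2 to compound 4 (0.28 log units; within the scatter). The value of compound 4 in this assay is therefore estimated at 4000 nM, within a range from 1000 nM to 20000 nM.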

Compound 4, half-maximal inhibitory concentration: 128000 nM
For compound 4 the middle estimate is 32-fold (1.51 log units) below the measured one, and the stated range ends below it.
By their numbers in this assay, from the lowest: compound 2; then compounds 3 and 4 (each within the scatter of the next); then compound 1.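

In this assay, this position proves highly sensitive to the exchange of groups: a 62-fold higher number from compound 2 to compound 4 (1.79 log units; beyond the scatter), with phenyl in place of trifluoromethyl on an aromatic carbon ortho to a large group. For the compounds shown here, the only earlier step, a 3.9-fold lower number from compound 1 to compound 3 (0.59 log units; beyond the scatter), concerned bromo in place of methyl on a different pair and was modest, whereas this step is large and gives the first reading of how far a change at this place can move the number on the core shared by the two compounds. Nothing available accounts for the size of this step, so the result records the change without explaining it.

With only trifluoromethyl and phenyl compared on this core, the compounds shown leave open whether the higher number follows from losing the trifluoromethyl or from introducing the phenyl. They also leave open where other groups at this place, such as a methoxy, an amine, a carboxylic acid or a longer chain, would fall relative to these two.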